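Swapping a para substituent on the cinnamamide aryl ring

The source may hold more compounds than are shown below. What is called first, only, known or untested is meant among the compounds shown, and "the series" means these compounds.

The compounds share a common core and differ only in the aromatic group carried on a double-bonded chain carbon bound to a double-bonded chain carbon. Compound 1 `COc1cc(/C=C/c2ccc(NC(=O)/C=C/c3cc(OC)c(O)c(OC)c3)cc2)cc(OC)c1` carries 4-hydroxy-3,5-dimethoxyphenyl there; in a functional assay on MDA-MB-231 cells (Homo sapiens) for inhibition, read by MTT assay, with a stated time of 48 h (on this read-out lower numbers stand for stronger inhibition and higher numbers for weaker inhibition), compound 1 gives 7130 nM. Compound 2 `COc1cc(/C=C/c2ccc(NC(=O)/C=C/c3ccc(C(F)(F)F)cc3)cc2)cc(OC)c1` carries 4-(trifluoromethyl)phenyl, and in this assay compound 2 gives 3520 nM. Compound 3 `COc1cc(/C=C/c2ccc(NC(=O)/C=C/c3ccccc3F)cc2)cc(OC)c1` carries 2-fluorophenyl; in this assay compound 3 gives 2380 nM. Among these, compound 2 stands second highest: there is a 2.0-fold lower number from compound 1 to compound 2 (0.31 log units; beyond the scatter), and a 1.5-fold lower number from compound 2 to compound 3 (0.17 log units; within the scatter), while a 3.0-fold lower number from compound 1 to compound 3 (0.48 log units; beyond the scatter).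

Compound 4 `COc1cc(/C=C/c2ccc(NC(=O)/C=C/c3ccc(Br)cc3)cc2)cc(OC)c1` is not yet measured. It differs from compound 2 in a single place: bromo in place of trifluoromethyl on an aromatic carbon. Among the compounds with values here, no measured step exchanges one small group for another on that ring. The closest guide is the step from compound 2 to compound 3, which exchanged the whole aromatic group and still stayed within the scatter, whereas the larger steps from compound 1 both removed the hydroxy-dimethoxy pattern that compound 4 also lacks. The expected step in this assay is therefore small, a 1.2-fold lower number from compound 2 to compound 4 (0.07 log units; within the scatter), with no clear direction beyond the scatter. Compound 4 is estimated at 3000 nM, within a range from 1400 nM to 6500 nM.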

Compound 4, half-maximal inhibitory concentration: 6160 nM
The estimate for compound 4 lay 2.1-fold (0.31 log units) below the measured number; low and high end bracket the measured number.
By their numbers in this assay, from the lowest: compounds 3, 2, 4 and 1 (each within the scatter of the next, the first and the last beyond it).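

Within the data shown here, exchanging trifluoromethyl for bromo is the first step here that changes only a small group on an aromatic carbon, while the rest of the 4-substituted phenyl stays in place; in this assay it gives a 1.8-fold higher number from compound 2 to compound 4 (0.24 log units; within the scatter), so a single bromine atom can stand in for the four heavy atoms of trifluoromethyl without a change that can be told apart from the scatter. Losing the hydroxy and dimethoxy groups no longer tracks with a lower number: compound 2 and compound 3 lie beyond the scatter of compound 1, but compound 4 goes against that pattern with a 1.2-fold lower number from compound 1 to compound 4 (0.06 log units; within the scatter), while a 2.6-fold higher number from compound 3 to compound 4 (0.41 log units; beyond the scatter) shows that the 2-fluorophenyl and 4-bromophenyl groups can be told apart. No measurement shown explains any of these steps.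

No compound shown carries the same group at two different places on this ring, so the gap to compound 3 cannot be divided between the choice of group and its place. On these data alone, how an amine, a carboxylic acid or a longer chain would behave at the place held by bromo also remains open.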